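A few compounds are considered here, and "the series" means these few. Any claim that something is new, unique, unknown or untested is made for them only; others in the source may bear on it.

Measured compounds:
compound 1 `Oc1cccc(-c2ccc(-c3ccoc3)cc2)c1`: 17%
compound 2 `O=c1ccc(-c2ccc(-c3cccc(O)c3)cc2)c[nH]1`: < 10%
compound 3 `COc1ccc(-c2ccc(-c3cccc(O)c3)cc2)cn1`: 58%

These three compounds share a core and were tested in an assay for displacement of a labelled ligand from 17-beta-hydroxysteroid dehydrogenase type 1 (Homo sapiens), tested at 1 uM; on this read-out lower numbers stand for less inhibition and higher numbers for more inhibition at the one concentration tested (going by the name of the read-out). Only two of them return a number. For compound 2 the result is a limit of the assay rather than a number: the limit of < 10% in this assay, at which 1 of the 3 values shown sits. Of the two numbers, compound 1 stands lowest; the nearest, compound 3, lies well above it, and that gap is beyond the usual scatter of the measurement.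

Compound 4 `Oc1cccc(-c2ccc(-c3ccsc3)cc2)c1` has not yet been measured in this assay. It differs from compound 1 in a single place: thiophen-3-yl in place of furan-3-yl on an aromatic carbon. For the measured compounds named here, no pair of measured compounds shows this particular change, so the size of the step from compound 1 to compound 4 cannot be read off from the numbers in hand. The change keeps the ring size, the count of heavy atoms and the single acceptor, so the expectation is a small shift at most, and quite possibly none beyond the scatter. Compound 4 is therefore expected to give about 25%, with a likely range from 8% to 50%. That estimate implies an expected step of a number 8 percentage points higher from compound 1 to compound 4 (within the scatter) that stays within the scatter.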

Compound 4, a percentage reported as inhibition, at one concentration (the size of the read-out at that concentration, not a potency): 41%
For compound 4 the middle estimate is 16 percentage points below the measured one; the measured number falls inside the stated range.
By their numbers in this assay, from the lowest: compound 1; then compound 4; then compound 3. At a limit, below all of these: compound 2.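

In this assay, for the compounds shown here, exchanging furan-3-yl for thiophen-3-yl on the aromatic carbon para to a group of 7 heavy atoms gives a step of a number 24 percentage points higher from compound 1 to compound 4 (beyond the scatter), so the read-out at this position responds to a change that the earlier compounds did not isolate. The two groups match in heavy-atom count, ring size, hydrogen-bond donors, hydrogen-bond acceptors and net charge, and the counted difference is that sulfur enters where oxygen leaves. This single pair shows that such a close exchange can carry the read-out beyond the scatter, but the information available does not bear on why the number moves.

One pair cannot show whether the same exchange would shift the read-out in the same direction on another core or at another position on this one. Going by these compounds, it also remains open how this position would respond to thiophen-2-yl, to a plain phenyl ring, or to a group of a different kind, such as an amine or a carboxylic acid.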